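The source may report more compounds than this note shows. Statements on the series, on what has been measured and on what is new or still open speak of the compounds shown alone.

Of the compounds shown here, two built on one shared core have been measured in a functional assay on NCI/ADR-RES cells (Homo sapiens) for inhibition, read by sulforhodamine B assay, with a stated time of 48 h, tested at 10 uM; a higher number here means more inhibition at the concentration tested (going by the name of the read-out), a lower number less inhibition. Compound 1 `CC(=O)c1ccc(-c2cn3ccnc3c(-c3ccc4ncn(C5CCCCC5)c4c3)n2)cc1` gives 4.17%. Compound 2 `Clc1ccc(-c2cn3ccnc3c(-c3ccc4ncn(C5CCCCC5)c4c3)n2)cc1` gives 11.1%, which stands highest of the two numbers, although the step of a number 6.9 percentage points higher from compound 1 to compound 2 (within the scatter) lies within the scatter, so the two numbers count as level and neither can be called higher than the other. Compound 3 `Fc1ccccc1-c1cn2ccnc2c(-c2ccc3ncn(C4CCCCC4)c3c2)n1` has not yet been measured in this assay. It differs from compound 2 in one place: 2-fluorophenyl in place of 4-chlorophenyl on an aromatic carbon. Within the data shown here, the only measured step, a number 6.9 percentage points higher from compound 1 to compound 2 (within the scatter), exchanged one group for another and was too small to count, and no measured step exchanges a chlorophenyl for a fluorophenyl, so there is no firm guide. A step of a number 2.1 percentage points lower from compound 2 to compound 3 (within the scatter) is expected, meaning nothing beyond the scatter. Compound 3 is therefore estimated at 9%, within a range from 0% to 25%.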

Compound 3, a percentage reported as inhibition, at one concentration (the size of the read-out at that concentration, not a potency): 4.51%
Compound 3: middle estimate off by 4.5 percentage points, on the high side; measured number inside the range.
By their numbers in this assay, from the lowest: compounds 1, 3 and 2 (each within the scatter of the next).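

The exchange of 4-chlorophenyl for 2-fluorophenyl brings a number 6.6 percentage points lower from compound 2 to compound 3 (within the scatter) in this assay, and the exchange of 4-acetylphenyl for 2-fluorophenyl brings a number 0.3 percentage points higher from compound 1 to compound 3 (within the scatter) in the same test. Three substituted phenyl groups on this aromatic carbon, differing both in the attached group and in where it sits on the phenyl ring, therefore give numbers that count as level, and none of the three stands out. No measured information is available to explain this result.

Going by these compounds, whether a phenyl ring carrying an amine or a carboxylic acid, or a longer chain in place of the phenyl ring, would shift the number at this position remains open. So does whether 4-fluorophenyl would match 2-fluorophenyl, a comparison that would separate the kind of group from its place on the phenyl ring.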